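The compounds below may be only part of what the source reports. "The series", "measured", "known", "first", "only" and "open" are said of these compounds alone.

For the measured compounds named here, in a functional assay on cells (Panel NCI-60 (60 carcinoma cell lines), Homo sapiens) for inhibition, read by colorimetric assay, with a stated time of 3 days (a lower number here means a stronger inhibitor of growth, a higher number a weaker inhibitor of growth), compound 1 (`COc1ccc(OC)c(NC(=O)CCCCCCNC(=O)C(O)(O)C(F)(F)F)c1`) has "not determined" (no result reported), so compound 2 (`COc1ccc(-c2cnc(NC(=O)CCCCCCNC(=O)C(O)(O)C(F)(F)F)s2)cc1`), at 1000 nM, holds the only number available and cannot yet be ranked against anything. Compound 3 (`O=C(CCCCCCNC(=O)C(O)(O)C(F)(F)F)Nc1ncc(-c2ccc(Br)cc2)s1`) keeps the shared core and changes one group: bromo in place of methoxy on an aromatic carbon. In words, this is bromo in place of methoxy on an aromatic carbon, turning 4-methoxyphenyl into 4-bromophenyl. Going by the values given here, no measured step exists to guide the call, so the expected change, a 1.3-fold lower number from compound 2 to compound 3 (0.10 log units; within the scatter), stays within the scatter, with no firm direction. For compound 3 the estimated value is 800 nM, with a range of 300 nM to 2500 nM.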

Compound 3, concentration for 50% growth inhibition: 930 nM
For compound 3 the middle estimate is 1.2-fold (0.07 log units) below the measured one; low and high end bracket the measured number.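

In this assay, for the compounds shown here, the exchange of methoxy for bromo gives a 1.1-fold lower number from compound 2 to compound 3 (0.03 log units; within the scatter) and so offers the first measured step on this carbon, para to a large group. The two groups, which differ in their atoms, read alike here. Nothing measured explains this result. 

Compound 1 has no number, so steps involving it cannot be read. On these data alone, whether an amine or a carboxylic acid in place of bromo would move the value, and whether a longer chain would do so, stays open.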